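This account rests on a few compounds, and the source may have more. Where it says the series, first, only, none or still open, it means among the compounds named here.

Measured so far:
Compound 1, `CCn1c(-c2cnc(C)nc2)nc2c(N[C@H]3CCN(C(=O)C4CC(F)(F)C4)C3)ncnc21`: 0.4 h
Compound 2, `CCn1c(-c2ccc(C(F)(F)F)nc2)nc2c(O[C@H]3CCN(C(=O)C4CCOC4)C3)ncnc21`: 2.3 h

In an ADME assay (Rattus norvegicus, strain Wistar Han) for metabolic stability (on this read-out lower numbers stand for a shorter-lived compound and higher numbers for a longer-lived compound), compound 1 gives 0.4 h, the lowest of the two numbers, so it is the shorter-lived of the pair. Among the measured compounds shown here, compound 2 gives 2.3 h in this assay, a gap that lies beyond the usual scatter; the two structures differ in several places at once, so the comparison says only that compound 2 lasts longer, not why.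

Compound 3, `CCC(=O)N1CC[C@H](Nc2ncnc3c2nc(-c2cnc(C)nc2)n3CC)C1`, keeps the core of compound 1 and changes only the group attached to the carbonyl carbon of the amide:

ethyl in place of 3,3-difluorocyclobutyl on a carbonyl carbon

For the measured compounds named here, no pair of measured compounds shares just this single change, so there is no directly comparable step to lean on. With so little to go on, the step from compound 1 to compound 3 is expected to be small, a 1.3-fold lower number from compound 1 to compound 3 (0.12 log units; within the scatter), and not clearly beyond the scatter in either direction. On that basis compound 3 is estimated to give 0.3 h in this assay, within a range of 0.1 h to 0.9 h.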

Compound 3, half-life: 1.5 h
Compound 3: middle estimate off by 5.0-fold (0.70 log units), on the low side; the whole stated range lies below it.
By their numbers in this assay, from the lowest: compound 1; then compounds 3 and 2 (each within the scatter of the next).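

Replacing the 3,3-difluorocyclobutyl with ethyl on the carbonyl carbon, with the rest of compound 1 unchanged, gives a 3.8-fold higher number from compound 1 to compound 3 (0.57 log units; beyond the scatter) in this assay. This shows that the group at this one place can by itself move the half-life by more than the usual scatter, which the first two compounds could not show, as they differ in several places at once. The data at hand offer no measurement that explains the change, so the step stands as a single observation without a known cause.

Going by these compounds, it remains open whether the difference follows the loss of the ring, the loss of the two fluorine atoms or the drop in group size, as these changes all arrive together in this one step. A plain cyclobutyl would keep the ring without the fluorine atoms, a butyl chain would offer a longer group with no ring, and neither these groups nor the same swap on the core of compound 2 can be judged from the compounds shown.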